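Aryl swap on the triazole nitrogen in a spiro series

The source may hold more compounds than are shown below. What is called first, only, known or untested is meant among the compounds shown, and "the series" means these compounds.

Two members of this series have been measured so far in a functional assay on A549 cells (Homo sapiens) for antiproliferative activity, read by MTT assay, with a stated time of 48 h; on this read-out higher numbers stand for weaker inhibition and lower numbers for stronger inhibition. Compound 1 `N#CC1=C(N)Oc2c(c3nc4ccccc4nc3c3ccccc23)C12C(=O)N(Cc1cnnn1-c1ccc([N+](=O)[O-])cc1)c1ccccc12` gives > 50000 nM in this assay, which is a limit of the assay and not a number. Compound 2 `N#CC1=C(N)Oc2c(N)cc3nc4ccccc4nc3c2C12C(=O)N(Cc1cnnn1-c1ccc(F)cc1)c1ccccc12` likewise reaches only the limit of this assay, > 50000 nM. Among the compounds with values here, both values therefore sit on the same limit (the limit of > 50000 nM in this assay, at which 2 of the 2 values shown sit), so no ordering between compound 1 and compound 2 can be drawn, and no measured step is available.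

Compound 3 `Cc1cc(C)cc(-n2nncc2CN2C(=O)C3(C(C#N)=C(N)Oc4c(N)cc5nc6ccccc6nc5c43)c3ccccc32)c1` differs from compound 2 by the change (3,5-dimethylphenyl in place of 4-fluorophenyl on an aromatic nitrogen). With nothing measured below the limit on either side, the expected size of the step from compound 2 to compound 3 is none beyond the scatter, as expressed by a step that the limit leaves unreadable from compound 2 to compound 3. Compound 3 is accordingly estimated at 60000 nM in this assay, within a range from 20000 nM to 200000 nM, and most likely it too will be reported only as a limit.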

Compound 3, half-maximal inhibitory concentration: 31200 nM
Beside the measured number, compound 3's estimate is 1.9-fold (0.28 log units) above it, within the range that was stated.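

In this assay, within the data shown here, compound 3 gives 31200 nM, the only value shown that is a number and not a limit. Placing 3,5-dimethylphenyl in place of 4-fluorophenyl on the aromatic nitrogen gives an at least 1.6-fold lower number from compound 2 to compound 3 (0.20 log units; that floor lies within the scatter), so this position can carry an aryl group with a readable value on the shared core. That floor alone does not establish a real gain, and the true size of the step stays hidden behind the limit of compound 2: the limit of > 50000 nM in this assay, at which 2 of the 3 values shown sit.

From the compounds shown here alone, whether the readable value goes with the two methyl groups or with the loss of the fluorine remains open, as an unsubstituted phenyl or a single methyl on the ring would be needed to separate them. Also open, going by these compounds, is whether a methoxy group or a carboxylic acid on this aryl ring would move the value further.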